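Replacing Bromo with Methoxy on the Aryl of Compound 2

This account rests on a few compounds, and the source may have more. Where it says the series, first, only, none or still open, it means among the compounds named here.

Compound 1: `COc1cc2c(Oc3ccc(NC(=O)c4nn(-c5ccccc5F)c(=O)c5ccccc45)cc3F)ccnc2cc1OCCCN1CCCCC1`, 160 nM
Compound 2: `COc1cc2c(Oc3ccc(NC(=O)c4nn(-c5ccc(Br)cc5)c(=O)c5ccccc45)cc3F)ccnc2cc1OCCCN1CCCCC1`, 410 nM

In a functional assay on NCI-H460 cells (Homo sapiens) for cytotoxicity, read by MTT assay, with a stated time of 72 h (a higher number here means a weaker inhibitor, a lower number a stronger inhibitor), compound 1 gives 160 nM and compound 2 gives 410 nM. Compound 2 thus stands at the highest of the two numbers shown, and the step of a 2.6-fold higher number from compound 1 to compound 2 (0.41 log units; beyond the scatter) separates it from compound 1. Compound 3, `COc1ccc(-n2nc(C(=O)Nc3ccc(Oc4ccnc5cc(OCCCN6CCCCC6)c(OC)cc45)c(F)c3)c3ccccc3c2=O)cc1`, differs from compound 2 by methoxy in place of bromo on an aromatic carbon. Going by the values given here, no measured step swaps one substituent for another on the 4-bromophenyl group, so the only step that bears on this change is a 2.6-fold higher number from compound 1 to compound 2 (0.41 log units; beyond the scatter), which was modest and involved a different ring pattern altogether. The exchange of one small group for another at the same ring is therefore expected to move the number little, if at all, beyond the scatter. Compound 3 is expected to give about 350 nM, within a range from 120 nM to 1000 nM. For compound 3 this means an expected step of a 1.2-fold lower number from compound 2 to compound 3 (0.07 log units; within the scatter).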

Compound 3, half-maximal inhibitory concentration: 840 nM
Compound 3: middle estimate off by 2.4-fold (0.38 log units), on the low side, within the range that was stated.
By their numbers in this assay, from the lowest: compound 1; then compound 2; then compound 3.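

In this assay, going by these compounds alone, the exchange of bromo for methoxy gives a 2.0-fold higher number from compound 2 to compound 3 (0.31 log units; beyond the scatter) and is the first direct change of the substituent on this ring, showing that the number responds to the group held at this place, although only one heavy atom separates the two groups. Set against the 2-fluorophenyl group, the 4-methoxyphenyl group gives a 5.3-fold higher number from compound 1 to compound 3 (0.72 log units; beyond the scatter) and so widens the gap that the 4-bromophenyl group had opened. No measured evidence here accounts for either step.

The compounds shown leave open whether the number would keep rising or fall back with an amine, a carboxylic acid or a longer ether chain at this place. They also leave open whether a 2-methoxyphenyl or 2-bromophenyl group would behave like the 2-fluorophenyl group of compound 1.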